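Trading Two Aryl Chlorines for One

A few compounds are considered here, and "the series" means these few. Any claim that something is new, unique, unknown or untested is made for them only; others in the source may bear on it.

Compound 2 `N/C(=N/NC(CC(=O)c1ccc(-n2ccnc2)cc1)c1ccc(Cl)cc1Cl)c1ccccn1` stands second highest of the three numbers measured in an ADME assay on Vero cells (Chlorocebus sabaeus) for cytotoxicity, read by MTT assay, with a stated time of 72 h (a lower number here means that less compound is tolerated, a higher number that more compound is tolerated), giving 27800 nM. Its nearest neighbour is compound 3 `N/C(=N/NC(CC(=O)c1ccc(-n2ccnc2)cc1)c1ccc([N+](=O)[O-])cc1)c1ccccn1`, which gives 23100 nM, so that a 1.2-fold lower number from compound 2 to compound 3 (0.08 log units; within the scatter) lies within the scatter; its furthest is compound 1 `N/C(=N/NC(CC(=O)c1ccc(-n2ccnc2)cc1)c1ccc(F)cc1)c1ccccn1`, which gives 78800 nM, with a 2.8-fold lower number from compound 1 to compound 2 (0.45 log units; beyond the scatter) and a 3.4-fold lower number from compound 1 to compound 3 (0.53 log units; beyond the scatter) both beyond the scatter. Compound 4 `N/C(=N/NC(CC(=O)c1ccc(-n2ccnc2)cc1)c1cccc(Cl)c1)c1ccccn1` carries 3-chlorophenyl in place of 2,4-dichlorophenyl on a saturated chain carbon bound to an amine nitrogen and a saturated chain carbon. The step from compound 1 to compound 2 bears most on this change, since it lowered the number modestly when the two chlorines arrived; with one chlorine leaving, compound 4 is expected to give back part of that, as a 1.6-fold higher number from compound 2 to compound 4 (0.21 log units; within the scatter) in this assay. Compound 4 is therefore estimated at 45000 nM, between 20000 nM and 110000 nM.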

Compound 4, half-maximal cytotoxic concentration: 68600 nM
Beside the measured number, compound 4's estimate is 1.5-fold (0.18 log units) below it; the measured number falls inside the stated range.
By their numbers in this assay, from the lowest: compounds 3 and 2 (each within the scatter of the next); then compounds 4 and 1 (each within the scatter of the next).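

At this saturated chain carbon, the single chlorine of 3-chlorophenyl separates clearly from the 2,4-dichlorophenyl group in this assay (a 2.5-fold higher number from compound 2 to compound 4 (0.39 log units; beyond the scatter)) and from 4-nitrophenyl (a 3.0-fold higher number from compound 3 to compound 4 (0.47 log units; beyond the scatter)). Yet it stays within the scatter of 4-fluorophenyl (a 1.1-fold lower number from compound 1 to compound 4 (0.06 log units; within the scatter)), so the presence of chlorine on this ring does not by itself go with the lower number of compound 2. No measurement shown here accounts for this difference. The compounds shown leave open which of the two chlorines of compound 2 matters, as neither 2-chlorophenyl nor 4-chlorophenyl stands among them. On these data alone, how unsubstituted phenyl would compare also remains open.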